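A few compounds are considered here, and "the series" means these few. Any claim that something is new, unique, unknown or untested is made for them only; others in the source may bear on it.

Compound 1, `CCC(COc1cccc(C(F)(F)F)c1)OC(=O)NCc1ccccc1`, and compound 2, `CCC(COc1ccccc1)OC(=O)NCc1ccccc1`, have the same shared core and differ in one aromatic substituent. In an assay for inhibition of zeta-carotene desaturase, chloroplastic/chromoplastic (Capsicum annuum), using a Dixon plot, with a stated time of 8 h (a higher number here means a weaker inhibitor, a lower number a stronger inhibitor), compound 1 gives > 100000 nM, which is a limit of the assay and not a number. In this assay compound 2 gives > 100000 nM, also a limit and not a number. For the measured compounds named here, the one measured step, a step that the two limits leave unreadable from compound 1 to compound 2, therefore cannot be read, since both of its ends sit at the limit of > 100000 nM in this assay, at which 2 of the 2 values shown sit. Compound 3, `CCC(COc1ccccc1Cl)OC(=O)NCc1ccccc1`, differs from compound 2 by chloro in place of hydrogen on an aromatic carbon. No measured step involves a chloro group, so nothing shown speaks for or against a change in potency from this substitution. Because compound 2 sits at > 100000 nM, a limit of the assay, the expected step that the limit leaves unreadable from compound 2 to compound 3 is about flat. The estimate for compound 3 in this assay is 150000 nM, with a range from 40000 nM to 600000 nM.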

Compound 3, half-maximal inhibitory concentration: > 100000 nM
Compound 3: only a limit was reported (the forecaster's own chance of this, stated with the estimate: 80%); the middle value is on the limit's open side.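

The step from compound 2 to compound 3 cannot be read, since both of its ends sit at a limit and not at a number: the limit of > 100000 nM in this assay, at which 3 of the 3 values shown sit. The compounds shown leave open whether trifluoromethyl or chloro changes potency at all in this assay, and what the true values of all three are.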